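Removing the isopropyl group from compound 1

The source may report more compounds than this note shows. Statements on the series, on what has been measured and on what is new or still open speak of the compounds shown alone.

compound 1 `Cc1cc2c(cc1C(=O)N=C(N)N)S(=O)(=O)CC2C(C)C`: 77 nM
compound 2 `Cc1cc2c(cc1C(=O)N=C(N)N)S(=O)(=O)C(C)(C)C2C`: 306 nM

In a functional assay for inhibition, with Homo sapiens as the target (on this read-out lower numbers stand for stronger inhibition and higher numbers for weaker inhibition), compound 1 holds the lower of the two numbers, at 77 nM. Compound 2 gives 306 nM, and the gap separating the two lies beyond the usual scatter. Going by the values given here, the two differ in more than one place, so their values give no clean step for any single group.

Compound 3 `Cc1cc2c(cc1C(=O)N=C(N)N)S(=O)(=O)CC2` has not yet been measured. It keeps the core of compound 1 but has hydrogen in place of isopropyl on a saturated ring carbon. Among the compounds with values here, no measured pair isolates this change, so the expectation rests on thin evidence. Within the data shown here, the only guide is compound 2 at 306 nM, which also lacks the isopropyl and sits higher. A moderate rise in this assay is therefore expected, towards weaker inhibition and probably just beyond the scatter, although no change beyond the scatter cannot be ruled out. The estimated change is a 2.6-fold higher number from compound 1 to compound 3 (0.41 log units; beyond the scatter). For compound 3 the expected value is 200 nM, with an estimated range of 60 nM to 650 nM.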

Compound 3, half-maximal inhibitory concentration: 587 nM
Compound 3: the middle estimate sits 2.9-fold (0.47 log units) below what was measured; measured number inside the range.
By their numbers in this assay, from the lowest: compound 1; then compounds 2 and 3 (each within the scatter of the next).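

In this assay, hydrogen in place of isopropyl on a saturated ring carbon, two ring bonds from the ring sulfur, gives a 7.6-fold higher number from compound 1 to compound 3 (0.88 log units; beyond the scatter). Going by these compounds alone, this is the first reading of a single change at this position, which compounds 1 and 2 could not give because they differ in more than one place. On the shared core, the isopropyl group is therefore worth a step beyond the scatter in favour of stronger inhibition, and compound 1, at 77 nM, keeps the lowest number of the three. Nothing at hand explains why the number moves this way at this position.

The compounds shown leave open how the read-out follows the size and shape of the carbon group here: an ethyl, a cyclopropyl, a tert-butyl or a phenyl group on the same ring carbon could fall short of isopropyl, match it or surpass it. Within the data shown here, they also leave open whether a hydroxyl group or an amine at this position would be tolerated, since the only groups compared in a clean step here are isopropyl and hydrogen.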